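Compound 4: a further swap of the group on the carbonyl

The source may hold more compounds than are shown below. What is called first, only, known or untested is meant among the compounds shown, and "the series" means these compounds.

Compound 1 `O=C(NCc1ccc(S(=O)(=O)c2ccccc2)cc1)c1cc2ccncc2s1` gives 21% in an ADME assay on microsomes from liver (Mus musculus) for metabolic stability, read by LC-MS, with a stated time of 30 min, tested at 1 uM; a higher number here means that more of the compound is left, a lower number that less of the compound is left
Compound 2 `O=C(NCc1ccc(S(=O)(=O)c2cccc(C(F)(F)F)c2)cc1)c1cc2cnccc2[nH]1` gives 49% in this assay
Compound 3 `O=C(NCc1ccc(S(=O)(=O)c2cccc(C(F)(F)F)c2)cc1)c1cnc2nccn2c1` gives 27% in this assay

Compound 3 (at 27%) lies within the scatter of compound 1 and clearly under compound 2 in this assay among these three numbers. Compound 4 `O=C(NCc1ccc(S(=O)(=O)c2cccc(C(F)(F)F)c2)cc1)c1cc2ccncc2s1` has not yet been measured. Its change from compound 3 is a group of 9 heavy atoms (7 carbon, 1 nitrogen, 1 sulfur; one five-membered aromatic ring with 1 hetero atom, one six-membered aromatic ring with 1 hetero atom) in place of a group of 9 heavy atoms (6 carbon, 3 nitrogen; one five-membered aromatic ring with 2 hetero atoms, one six-membered aromatic ring with 2 hetero atoms), on a carbonyl carbon and the rest of the structure stays the same.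

Two measurements bear on this change. Among the compounds with values here, the one measured step at this place is a number 22 percentage points lower from compound 2 to compound 3 (beyond the scatter) and it shows that exchanging the group on the carbonyl carbon can move the number beyond the scatter, though that step involves a different pair of groups. Compound 1 carries the entering group but lacks the trifluoromethyl group, and compound 1 gives 21% in this assay which is close to the starting point. Taken together, these suggest no large move. The estimate for this change is a number 3 percentage points higher from compound 3 to compound 4 (within the scatter) and this expected step stays within the scatter. The expected value for compound 4 is 30% with an estimated range from 16% to 46% in this assay once measured.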

Compound 4, percent of the compound remaining: 35%
Compound 4: middle estimate off by 5 percentage points, on the low side, within the range that was stated.
By their numbers in this assay, from the lowest: compounds 1, 3 and 4 (each within the scatter of the next, the first and the last beyond it); then compound 2.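

With the trifluoromethyl group held in place, the exchange on the carbonyl carbon gives a number 8 percentage points higher from compound 3 to compound 4 (within the scatter) in this assay, so this assay does not separate these two groups at this position. The group of compound 2 remains apart from both, now with a second step beyond the scatter, a number 14 percentage points lower from compound 2 to compound 4 (beyond the scatter), which adds to the drop already seen with compound 3. Within the data shown here, the result also gives the first reading at another place in the structure: trifluoromethyl in place of hydrogen on an aromatic carbon gives a number 14 percentage points higher from compound 1 to compound 4 (beyond the scatter), a step beyond the scatter that rests on this single pair with one group on the carbonyl carbon.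

No measurement at hand accounts for any of these steps. Going by these compounds, it remains open whether the trifluoromethyl step would be of similar size with the groups of compound 2 or compound 3 on the carbonyl carbon, and how a nitrile, a methoxy group or an amine in place of the trifluoromethyl group would read in this assay.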